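Chloro to fluoro on the shared core

The compounds below may be only part of what the source reports. "The series", "measured", "known", "first", "only" and "open" are said of these compounds alone.

Compound 3 `Clc1ccccc1OCC1=NCCO1` sits lowest of the three numbers in a functional assay on the whole organism for inhibition, with Rattus norvegicus as the target, read by paw edema, with a stated time of 30 min, at a dose of 40 mg/kg by the oral route (on this read-out lower numbers stand for a weaker effect and higher numbers for a stronger effect at the one dose given), at 22.2%, though both neighbours lie within the scatter of it: compound 1 `Brc1ccccc1OCC1=NCCO1` gives 29.1% and compound 2 `Cc1ccccc1OCC1=NCCO1` gives 29.5%. Compound 4 `Fc1ccccc1OCC1=NCCO1` differs from compound 3 by fluoro in place of chloro on an aromatic carbon. Among the measured compounds shown here, the steps that bear on this swap are a number 6.9 percentage points lower from compound 1 to compound 3 (within the scatter) and a number 7.3 percentage points lower from compound 2 to compound 3 (within the scatter), both within the scatter; a number 0.4 percentage points higher from compound 1 to compound 2 (within the scatter) is likewise flat. With three different substituents at this place giving numbers inside the usual scatter of one another, no step beyond the scatter is expected for fluoro. The estimate for compound 4 is therefore 26%, between 14% and 38%, a step of a number 3.8 percentage points higher from compound 3 to compound 4 (within the scatter) that is expected to stay within the scatter.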

Compound 4, a percentage reported as inhibition, in the whole organism at one dose (the size of the read-out at that dose, not a potency): 30.5%
Compound 4: middle estimate off by 4.5 percentage points, on the low side; the measured number falls inside the stated range.
By their numbers in this assay, from the lowest: compounds 3, 1, 2 and 4 (each within the scatter of the next).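

In this assay the change to fluoro gives a number 8.3 percentage points higher from compound 3 to compound 4 (within the scatter) and a number 1 percentage points higher from compound 2 to compound 4 (within the scatter) and a number 1.4 percentage points higher from compound 1 to compound 4 (within the scatter). This position on the aromatic ring now holds bromo, methyl, chloro and fluoro with no step beyond the scatter, so these four substituents cannot be separated on this read-out. Nothing available explains this flat result.

As far as these compounds go, whether an amine, a carboxylic acid or a longer chain at this place would give a step beyond the scatter remains open. So does the effect of any of these four substituents elsewhere on the ring.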